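This account rests on a few compounds, and the source may have more. Where it says the series, first, only, none or still open, it means among the compounds named here.

Measured compounds in an ADME assay on the whole organism (strain Sprague-Dawley) for pharmacokinetics, with Rattus norvegicus as the target, at a dose of 1 mg/kg by the intravenous route; a lower number here means slower removal, a higher number faster removal of the compound: compound 1 `Cn1c(C2CCOCC2)nc(C(=O)NCc2ccc(F)cc2N2CCN(C(C)(C)C)S2(=O)=O)c(O)c1=O` gives 41 mL/min/kg. Compound 2 `Cn1c(C2CCOCC2)nc(C(=O)NCc2ccc(F)cc2)c(O)c1=O` gives 2.6 mL/min/kg. Compound 3 `Cc1ncnn1-c1cc(F)ccc1CNC(=O)c1nc(C2CCOC2)n(C)c(=O)c1O` gives 37 mL/min/kg.

Compound 3 stands second highest of the three numbers. Its number sits within the scatter of compound 1 and far above compound 2; the two compounds with a ring group on the aromatic carbon next to the benzylic amide both return high numbers, and the compound that carries only hydrogen there returns a low one.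

Among the measured compounds shown here, the only step that changes one place is a 16-fold lower number from compound 1 to compound 2 (1.20 log units; beyond the scatter). It says that taking the large ring group away from that aromatic carbon lowers the number strongly. For the measured compounds named here, no step in the data swaps one ring group for another at that position.

Compound 4 `COCCN1CCN(c2cc(F)ccc2CNC(=O)c2nc(C3CCOC3)n(C)c(=O)c2O)C1=O` differs from compound 3 by 3-(2-methoxyethyl)-2-oxoimidazolidin-1-yl in place of 5-methyl-1H-1,2,4-triazol-1-yl on an aromatic carbon. Compound 4 keeps a ring group at the position where compound 1 and compound 3 each carry one, and both of those give high numbers, so no drop toward compound 2 is expected. Because the step of a 16-fold lower number from compound 1 to compound 2 (1.20 log units; beyond the scatter) only covers removal, the size of the exchange is uncertain; the expected step of a 1.1-fold higher number from compound 3 to compound 4 (0.06 log units; within the scatter) is within the scatter or a little upward. Compound 4 is estimated at 42 mL/min/kg, with a range from 20 mL/min/kg to 85 mL/min/kg.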

Compound 4, clearance: 15 mL/min/kg
Compound 4: middle estimate off by 2.8-fold (0.45 log units), on the high side; measured number outside the range, below it.
By their numbers in this assay, from the lowest: compound 2; then compound 4; then compounds 3 and 1 (each within the scatter of the next).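

In this assay, a 2.5-fold lower number from compound 3 to compound 4 (0.39 log units; beyond the scatter) comes with 3-(2-methoxyethyl)-2-oxoimidazolidin-1-yl in place of 5-methyl-1H-1,2,4-triazol-1-yl, and this is the only step shown that exchanges one ring group for another on this aromatic carbon, ortho to a large group and meta to a fluoro group. The earlier step, a 16-fold lower number from compound 1 to compound 2 (1.20 log units; beyond the scatter), showed only what removal of a different ring group does on a different core, whereas this one shows that the number also depends on which ring group is present, so carrying a ring group there does not by itself fix the number at the level of compound 3. No measurement in hand bears on why the number moves with this exchange.

As far as these compounds go, it remains open whether the lower number follows the 2-oxoimidazolidin-1-yl ring or its 2-methoxyethyl chain, and a plain methyl in place of that chain would separate the two. Also open, from the compounds shown here alone, is how a ring group carrying an amine or a carboxylic acid at this aromatic carbon would compare on the core of compound 4, and how far a hydrogen there would lower the number on that same core.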